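Sulfamoyl in place of chloro on a shared core

This account rests on a few compounds, and the source may have more. Where it says the series, first, only, none or still open, it means among the compounds named here.

Measured compounds:
compound 1, `Cc1ccc(-c2nn(-c3ccc(S(N)(=O)=O)cc3)cc2/C=N\c2ccccc2)cc1`, giving 58.1%
compound 2, `Cc1ccc(-c2nn(-c3ccc(Cl)cc3)cc2/C=C\C(=O)c2ccc(Cl)cc2)cc1`, giving 49.2%

Of the compounds shown here, two have been measured in a functional assay on the whole organism (strain Wistar albino) for inhibition, with Rattus norvegicus as the target, read by paw edema, with stated times of 1 h and 2 h, at a dose of 0.32 mmol/kg by the intraperitoneal route; on this read-out higher numbers stand for more inhibition at the one dose given (going by the name of the read-out) and lower numbers for less inhibition. Compound 2 stands at 49.2%, and compound 1 at 58.1%; these two numbers lie within the scatter of each other, so nothing separates them with confidence. For the measured compounds named here, the two structures differ in more than one place, so no single step between them can be read.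

Compound 3, `Cc1ccc(-c2nn(-c3ccc(S(N)(=O)=O)cc3)cc2/C=C\C(=O)c2ccc(Cl)cc2)cc1`, has not been measured. It differs from compound 2 in one place: sulfamoyl in place of chloro on an aromatic carbon. The same sulfamoylphenyl group is present in compound 1, whose reading in this assay is within the scatter of compound 2. On that basis no step beyond the scatter is expected, and the estimated change a number 5.8 percentage points higher from compound 2 to compound 3 (within the scatter) is small and upward at most. Compound 3 is therefore expected to give about 55%, between 42% and 68%.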

Compound 3, a percentage reported as inhibition, in the whole organism at one dose (the size of the read-out at that dose, not a potency): 53.3%
Estimate against measurement, compound 3: 1.7 percentage points above; the measured number falls inside the stated range.
By their numbers in this assay, from the lowest: compounds 2, 3 and 1 (each within the scatter of the next).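

In this assay, the exchange of 4-chlorophenyl for 4-sulfamoylphenyl can now be read on its own, and it amounts to a number 4.1 percentage points higher from compound 2 to compound 3 (within the scatter), so the two groups are not told apart at this position, on an aromatic carbon para to a large group. With the sulfamoyl group held constant, the group of 11 heavy atoms in place of the group of 8 heavy atoms gives a number 4.8 percentage points lower from compound 1 to compound 3 (within the scatter), so that exchange is not resolved either. Nothing at hand offers a reason for either reading.

The compounds shown leave open whether another group at this position, such as a carboxylic acid or an amine, would move the reading beyond the scatter. On these data alone, how these compounds compare at other doses also remains open.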